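The source may hold more compounds than are shown below. What is called first, only, known or untested is meant among the compounds shown, and "the series" means these compounds.

In a functional assay on MCF7 cells (Homo sapiens) for antiproliferative activity, read by sulforhodamine B assay, with a stated time of 48 h (a higher number here means a weaker inhibitor, a lower number a stronger inhibitor), three compounds with a shared core differ only in the group on a sulfonamide nitrogen. Compound 1 `CCc1ccccc1NS(=O)(=O)c1ccc(N2CCNC2=O)cc1` gives 350 nM, compound 2 `O=C1NCCN1c1ccc(S(=O)(=O)Nc2ccc(I)cc2)cc1` gives 600 nM, and compound 3 `O=C1NCCN1c1ccc(S(=O)(=O)Nc2cccc(Br)c2)cc1` gives 100 nM. Compound 3 thus has the lowest number of the three and is the strongest inhibitor among them, as shown by a 3.5-fold lower number from compound 1 to compound 3 (0.54 log units; beyond the scatter) and by a 6.0-fold lower number from compound 2 to compound 3 (0.78 log units; beyond the scatter), both modest. By contrast, a 1.7-fold higher number from compound 1 to compound 2 (0.23 log units; within the scatter) does not separate the other two.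

Compound 4 `Cc1cc(C)cc(NS(=O)(=O)c2ccc(N3CCNC3=O)cc2)c1` carries 3,5-dimethylphenyl in place of 3-bromophenyl on a sulfonamide nitrogen. Among the measured compounds shown here, no measured step makes this exact exchange, so the evidence is indirect. The closest comparison is the 2-ethylphenyl of compound 1, which stands behind compound 3 by a 3.5-fold lower number from compound 1 to compound 3 (0.54 log units; beyond the scatter). A small move toward a higher number is therefore expected in this assay, possibly no larger than the scatter. The expected change is a 1.8-fold higher number from compound 3 to compound 4 (0.26 log units; within the scatter). Compound 4 is estimated at 180 nM, with an expected range of 60 nM to 550 nM.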

Compound 4, half-maximal inhibitory concentration: 100 nM
Estimate against measurement, compound 4: 1.8-fold (0.26 log units) above; the range from low to high includes it.
By their numbers in this assay, from the lowest: compounds 3 and 4 (each within the scatter of the next); then compounds 1 and 2 (each within the scatter of the next).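

In this assay, the group on the sulfonamide nitrogen need not carry bromine to reach the level of compound 3: 3,5-dimethylphenyl in place of 3-bromophenyl gives no change at the digits printed from compound 3 to compound 4 (within the scatter). The separation from the other two compounds also holds for this new group, with a 6.0-fold lower number from compound 2 to compound 4 (0.78 log units; beyond the scatter) and with a 3.5-fold lower number from compound 1 to compound 4 (0.54 log units; beyond the scatter), so the lead that compound 3 held alone is now shared by two different substituted phenyl groups. Nothing measured here explains why these two groups match.

The compounds shown leave open whether a phenyl group bearing an amine or a carboxylic acid would stay at this level. They also do not show what a longer alkyl chain in place of the phenyl ring on the sulfonamide nitrogen would give.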